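The source may report more compounds than this note shows. Statements on the series, on what has been measured and on what is new or still open speak of the compounds shown alone.

Working notes on the series.

In an assay on CHO cells for displacement of a labelled ligand from 5-hydroxytryptamine receptor 7 (Homo sapiens) (on this read-out higher numbers stand for weaker inhibition and lower numbers for stronger inhibition), compound 1 `CCC1(CCCCN2CCN(c3ccc(Cl)cc3)CC2)C(=O)Nc2ccccc21` gives 0.38 nM; 0.38 nM (2 entries) and compound 2 `CCC1(CCCCN2CCN(c3cccc(OC)c3)CC2)C(=O)Nc2ccccc21` gives 2.55 nM. Among the compounds with values here, compound 3 `CCC1(CCCCN2CCN(c3ccc(OC)cc3)CC2)C(=O)Nc2ccccc21` gives 25.4 nM in this assay, the highest of the two single numbers so far; its nearest neighbour is compound 2, and the one step that joins them, a 10-fold higher number from compound 2 to compound 3 (1.00 log units; beyond the scatter), shows that moving the methoxy group on the phenyl ring attached to the ring nitrogen shifts the number well beyond the scatter.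

Compound 4 `CCC1(CCCCN2CCN(c3ccccc3Cl)CC2)C(=O)Nc2ccccc21` is not yet measured. The change from compound 3 is 2-chlorophenyl in place of 4-methoxyphenyl on an amine nitrogen in a ring. Within the data shown here, no measured step involves a 2-chlorophenyl group; the only direct evidence is the chloro-bearing compound 1 with 0.38 nM; 0.38 nM (2 entries) and the 4-methoxy compound 3 with 25.4 nM, together with the step from compound 2 to compound 3 noted above. A return towards the lower numbers of compound 1 and compound 2 is therefore expected, but with wide uncertainty. Compound 4 is expected to give about 3 nM in this assay, within 0.5 nM to 20 nM, an expected step of an 8.5-fold lower number from compound 3 to compound 4 (0.93 log units; beyond the scatter).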

Compound 4, inhibition constant: 5.11 nM
Estimate against measurement, compound 4: 1.7-fold (0.23 log units) below; measured number inside the range.
By their numbers in this assay, from the lowest: compounds 2 and 4 (each within the scatter of the next); then compound 3.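

In this assay the 2-chlorophenyl group, on the same amine nitrogen in a ring, gives a 5.0-fold lower number from compound 3 to compound 4 (0.70 log units; beyond the scatter) and so shows that the high number of compound 3 does not extend to every substituted phenyl group at this position. Set against 3-methoxyphenyl, the same group gives a 2.0-fold higher number from compound 2 to compound 4 (0.30 log units; within the scatter) and cannot be told apart from it, which leaves 4-methoxyphenyl as the one group of these three that stands apart. Nothing available on these compounds accounts for the differences.

Still open, from the compounds shown here alone, is how an amine, a nitrile or a carboxylic acid on the phenyl ring would read in this assay. Also open, going by these compounds, is whether a phenyl ring with no substituent would fall nearer to compound 3 or to compound 4.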